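The compounds below may be only part of what the source reports. "The series", "measured", "known", "first", "only" and "open" are said of these compounds alone.

Compounds measured in an assay on HEK293 cells for agonist activity at transient receptor potential cation channel subfamily M member 8 (Homo sapiens), read by fluorescence and calcium flux, with a stated time of 15 min; a lower number here means that less compound is needed, a higher number that more compound is needed for the effect:
compound 1, `Cc1ccc(OCC(=O)N(Cc2cccs2)c2c(C)n[nH]c2C)cc1`, 0.3 nM;
compound 2, `COCCN(Cc1cccs1)C(=O)COc1ccc(C)cc1`, 400 nM;
compound 3, `Cc1ccc(OCC(=O)N(Cc2cccs2)c2ncco2)cc1`, 0.3 nM.

Compound 3 stands level with compound 1 at the digits shown, and the two together hold the lowest numbers of the three; compound 2 stands far above both, as the step of a 1300-fold lower number from compound 2 to compound 3 (3.12 log units; beyond the scatter) shows.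

Compound 4, `CON(Cc1cccs1)C(=O)COc1ccc(C)cc1`, has not yet been measured in this assay. It differs from compound 3 in one place: methoxy in place of 1,3-oxazol-2-yl on an amide-type nitrogen. The aromatic ring on the amide-type nitrogen is thus replaced by a small chain group.

Going by the values given here, two measured steps bear on this. In a 1300-fold higher number from compound 1 to compound 2 (3.12 log units; beyond the scatter) a ring on the same nitrogen gave way to a chain, and the number rose sharply. In a 1300-fold lower number from compound 2 to compound 3 (3.12 log units; beyond the scatter) the chain gave way to a ring, and the number fell by the same amount. Both say that a ring on this nitrogen goes with a low number and a chain with a high one. Methoxy is a chain group, so a large rise is expected for compound 4 in this assay.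

Compound 4 is therefore estimated at 300 nM, within 30 nM to 3000 nM, a step of a 1000-fold higher number from compound 3 to compound 4 (3.00 log units; beyond the scatter), with the width reflecting that methoxy is shorter than the chain in compound 2.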

Compound 4, half-maximal effective concentration: 10 nM
Beside the measured number, compound 4's estimate is 30-fold (1.48 log units) above it, and the stated range ends above it.
By their numbers in this assay, from the lowest: compounds 1 and 3 (each within the scatter of the next); then compound 4; then compound 2.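

In this assay the amide-type nitrogen does not sort simply into ring and chain: the step of a 40-fold lower number from compound 2 to compound 4 (1.60 log units; beyond the scatter) shows that two groups without a ring can lie far apart, so the identity of the chain matters and not only the loss of the ring. Methoxy, with its 2 heavy atoms, still does not reach the level of either ring, as seen in a 33-fold higher number from compound 3 to compound 4 (1.52 log units; beyond the scatter) and in a 33-fold higher number from compound 1 to compound 4 (1.52 log units; beyond the scatter), so the ring compounds keep a clear advantage over the better of the two chains. No measurement shown here accounts for the size of these steps or for the gap between the two chains.

Two chains cannot show whether the number climbs steadily with chain length, and a plain ethyl group or a longer chain such as 3-methoxypropyl on the same nitrogen would help to settle that. As far as these compounds go, it also remains open whether a chain ending in an amine or a carboxylic acid would behave like these two, and whether a six-membered ring such as pyridin-2-yl would match the low numbers of the two five-membered rings.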